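A Second Hydroxy Group on the Pendant Phenyl

A few compounds are considered here, and "the series" means these few. Any claim that something is new, unique, unknown or untested is made for them only; others in the source may bear on it.

Compound 1 `CCC1=C(O)c2c(oc(-c3ccc(O)cc3)cc2=O)C(CC)(CC)C1=O` was tested in a functional assay on KB cells (Homo sapiens) for antiproliferative activity, read by sulforhodamine B assay, with a stated time of 3 days (on this read-out lower numbers stand for an effect already at smaller amounts and higher numbers for an effect only at larger amounts of compound), and gives 20.6 uM, the lowest of the two numbers recorded. Compound 3 `CCC1=C(O)c2c(oc(-c3ccc(C)c(Cl)c3)cc2=O)C(CC)(CC)C1=O` gives 39 uM in this assay, and the step of a 1.9-fold higher number from compound 1 to compound 3 (0.28 log units; within the scatter) stays within the scatter. For compound 2 `CCC1=C(O)c2c(oc(-c3ccccc3F)cc2=O)C(CC)(CC)C1=O` this assay reports only a limit, > 56.2 uM. The step of an at least 2.7-fold higher number from compound 1 to compound 2 (0.43 log units; beyond the scatter) lies beyond the scatter. Compound 4 `CCC1=C(O)c2c(oc(-c3ccc(O)c(O)c3)cc2=O)C(CC)(CC)C1=O` differs from compound 1 by hydroxy in place of hydrogen on an aromatic carbon. For the measured compounds named here, no measured step adds a group to the 4-hydroxyphenyl itself; the two that replace it either leave the number within the scatter or push it to a limit. One therefore expects for compound 4 a step of a 1.0-fold lower number from compound 1 to compound 4 (0.01 log units; within the scatter) within the scatter, and estimates 20 uM with a range from 8 uM to 50 uM.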

Compound 4, concentration for half-maximal effect: 10 uM
Beside the measured number, compound 4's estimate is 2.0-fold (0.30 log units) above it; the range from low to high includes it.
By their numbers in this assay, from the lowest: compound 4; then compounds 1 and 3 (each within the scatter of the next). At a limit, above all of these: compound 2.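

In this assay the added hydroxy gives a 2.1-fold lower number from compound 1 to compound 4 (0.31 log units; beyond the scatter) and is the only step shown that adds a group to the 4-hydroxyphenyl and moves the number beyond the scatter. The 3,4-dihydroxyphenyl also stands clear of the other two replacements, with a 3.9-fold lower number from compound 3 to compound 4 (0.59 log units; beyond the scatter) and an at least 5.6-fold lower number from compound 2 to compound 4 (0.74 log units; beyond the scatter) as the two steps. The second of these is only a floor, since compound 2 stands at a limit: the limit of > 56.2 uM in this assay, at which 1 of the 4 values shown sits. As far as these compounds go, what a methoxy or an amine would do at this place, ortho to a hydroxy group, stays open.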